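Cyano to carboxy on the shared core

The compounds below may be only part of what the source reports. "The series", "measured", "known", "first", "only" and "open" are said of these compounds alone.

compound 1 `N#Cc1ccc2occc(=O)c2c1`: "nd(insoluble)" (no result reported)
compound 2 `CN(C(=O)c1cc(=O)c2ccccc2o1)c1nnn[nH]1`: > 18 ug/mL

In a functional assay on cells (Mast cell, Rattus norvegicus) for inhibition, with a stated time of 15 min (a higher number here means that more compound is needed for the effect, a lower number that less compound is needed), compound 1 gives "nd(insoluble)" (no result reported), so it has no number and no place on the scale. Compound 2 gives only a limit, > 18 ug/mL, and no number. The unmeasured compound 3 `O=C(O)c1ccc2occc(=O)c2c1` keeps the core of compound 1. The change is carboxy in place of cyano on an aromatic carbon, para to a fused ring. Among the compounds with values here, with no number for compound 1, no step in this assay can be sized from it. The expected direction is toward a weak result, with a high concentration needed, and the limit of compound 2 at > 18 ug/mL is the only anchor. Compound 3 is estimated at 30 ug/mL, with an expected range of 8 ug/mL to 100 ug/mL.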

Compound 3, concentration for half-maximal effect: > 18 ug/mL
Compound 3: only a limit was reported; the forecaster's own chance of this, stated with the estimate: 60%; the middle value is on the limit's open side.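

No step can be read between compound 1 and compound 3, as in this assay compound 1 has no number on the scale. Compound 3 gives > 18 ug/mL as a limit only. The compounds shown leave open whether replacing cyano with carboxy changes the concentration needed at all.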